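A few compounds are considered here, and "the series" means these few. Any claim that something is new, unique, unknown or untested is made for them only; others in the source may bear on it.

Measured so far:
compound 1, `Cc1nn(C)c2c1C(c1ccccc1)=NCC(=O)N2`, 10 mg/kg
compound 2, `CCc1nn(C)c2c1C(c1ccccc1)=NCC(=O)N2`, 2.5 mg/kg
compound 3, `CCc1nn(C)c2c1C(c1ccccc1Cl)=NCC(=O)N2`, 2.5 mg/kg

All three were run in a functional assay on the whole organism (strain Holtzman) with Rattus norvegicus as the target; a lower number here means that less compound is needed, a higher number that more compound is needed for the effect. The change methyl in place of hydrogen on a saturated chain carbon bound to an aromatic carbon gave a 4.0-fold lower number from compound 1 to compound 2 (0.60 log units; beyond the scatter). The change no change at the digits printed from compound 2 to compound 3 (within the scatter) followed. Compound 4, `CC(C)c1nn(C)c2c1C(c1ccccc1Cl)=NCC(=O)N2`, is not yet measured; it differs from compound 3 by methyl in place of hydrogen on a saturated chain carbon bound to an aromatic carbon and a saturated chain carbon. This is the same kind of change as that from compound 1 to compound 2, but not the same: there the place was a saturated chain carbon bound to an aromatic carbon only, here it is a saturated chain carbon bound to an aromatic carbon and a saturated chain carbon. The difference between the two cores is not broken down here. Because the earlier step of a 4.0-fold lower number from compound 1 to compound 2 (0.60 log units; beyond the scatter) was modest, a smaller step is expected for compound 4 in this assay, namely a 1.7-fold lower number from compound 3 to compound 4 (0.22 log units; within the scatter). Compound 4 is thus estimated at 1.5 mg/kg, with a range from 0.6 mg/kg to 5 mg/kg.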

Compound 4, minimum effective dose: > 40 mg/kg
Compound 4 was reported as a limit; the forecaster's own chance of this, stated with the estimate: 5%; middle value at least 26-fold (1.42 log units) away from the limit.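

In this assay, the added methyl gave an at least 16-fold higher number from compound 3 to compound 4 (1.20 log units; beyond the scatter), so the effect of this change did not carry from one core to the other: the same change on two cores in this assay, a 4.0-fold lower number (0.60 log units; beyond the scatter) from compound 1 to compound 2 and an at least 16-fold higher number (1.20 log units; beyond the scatter) from compound 3 to compound 4, at least 64-fold (1.80 log units) apart, beyond the scatter of two such steps

Compound 4 gives > 40 mg/kg, which is a limit of the assay and not a number. With one pair on each core, the data do not show which difference is responsible, as the place of the methyl differs between the two steps and compound 3 carries a chloro absent from compound 1.

The compounds shown leave open whether the isopropyl result holds without the chloro. They also leave open how a longer chain, such as n-propyl, or a cyclopropyl group would read in place of the ethyl.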